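Replacing the Chloro of Compound 2

The source may report more compounds than this note shows. Statements on the series, on what has been measured and on what is new or still open speak of the compounds shown alone.

For the measured compounds named here, in a functional assay on HepG2 cells (Homo sapiens) for cytotoxicity, read by MTT assay, with a stated time of 72 h (a lower number here means a stronger inhibitor, a higher number a weaker inhibitor), compound 2 `Cn1cccc1-c1nc2cc(NC(=O)CCl)ccc2[nH]1` gives 1800 nM, the only exact number so far. Compound 1 `CCN1CCN(CC(=O)Nc2ccc3[nH]c(-c4cccn4C)nc3c2)CC1` is reported as > 50000 nM, which is a limit of the assay and not a number.

Compound 3 `CCN1CCN(CCC(=O)Nc2ccc3[nH]c(-c4cccn4C)nc3c2)CC1` differs from compound 2 as follows: (4-ethylpiperazin-1-yl)methyl in place of chloro on a saturated chain carbon bound to a carbonyl carbon. Thus (4-ethylpiperazin-1-yl)methyl stands in place of chloro on a saturated chain carbon bound to a carbonyl carbon.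

Going by the values given here, one measured step bears on this: an at least 27-fold lower number from compound 1 to compound 2 (1.44 log units; beyond the scatter), with chloro in place of 4-ethylpiperazin-1-yl at that same kind of carbon. The new change runs the opposite way, so a large move towards a higher number is expected in this assay, though this rests on a single step. The expected change is a 17-fold higher number from compound 2 to compound 3 (1.22 log units; beyond the scatter). For compound 3 the estimate is 30000 nM, with an expected range of 9000 nM to 60000 nM.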

Compound 3, half-maximal inhibitory concentration: > 50000 nM
Compound 3 was reported as a limit; the forecaster's own chance of this, stated with the estimate: 55%; middle value at least 1.6-fold (0.22 log units) away from the limit.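

Putting (4-ethylpiperazin-1-yl)methyl in place of chloro on a saturated chain carbon bound to a carbonyl carbon gives an at least 27-fold higher number from compound 2 to compound 3 (1.44 log units; beyond the scatter) in this assay. The earlier compounds shown here showed this large move only for 4-ethylpiperazin-1-yl, so compound 3 shows that it also occurs with the larger (4-ethylpiperazin-1-yl)methyl group, at least in this one further case. The step from compound 1 to compound 3 cannot be read, since both values are limits of the assay: the limit of > 50000 nM in this assay, at which 2 of the 3 values shown sit.

Going by these compounds, how far compound 1 and compound 3 really lie from compound 2 therefore stays unknown. The compounds shown also leave open whether the higher number follows from losing the chloro or from gaining the piperazine ring, which a bromo group or a small amine such as dimethylamino at this carbon would help to separate.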